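The source may hold more compounds than are shown below. What is called first, only, known or untested is meant among the compounds shown, and "the series" means these compounds.

Compound 1, `NC1=N[C@@H](c2ccccc2)CO1`, serves as the reference point of this small set. In a functional assay on HEK293 cells for agonist activity at trace amine-associated receptor 1 (Homo sapiens), read by cAMP accumulation, with a stated time of 30 min (a lower number here means a smaller maximal response, a higher number a larger maximal response), compound 1 reaches 104%. Compound 2, `CCN(C[C@H]1COC(N)=N1)c1ccccc1`, carries a different core; in this assay compound 2 reaches 87%. The difference between the two cores is not broken down here. Compound 3, `CCN(C[C@H]1COC(N)=N1)c1cccc(Cl)c1`, differs from compound 2 by chloro in place of hydrogen on an aromatic carbon, and in this assay compound 3 reaches 85%, which is a number 2 percentage points lower from compound 2 to compound 3 (within the scatter).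

Compound 4, `NC1=N[C@@H](c2ccccc2Cl)CO1`, is not yet measured. It differs from compound 1 by chloro in place of hydrogen on an aromatic carbon. This is the same kind of change as that from compound 2 to compound 3, but the surroundings differ: in compound 3 the chloro sits meta to a large group, whereas in compound 4 it sits ortho to a group of 6 heavy atoms. Because a number 2 percentage points lower from compound 2 to compound 3 (within the scatter) lies within the scatter, the step from compound 1 to compound 4 in this assay is expected to be small as well, about a number 6 percentage points lower from compound 1 to compound 4 (within the scatter). Compound 4 is therefore estimated to reach 98% in this assay, most likely between 80% and 112%.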

Compound 4, largest response reached (Emax), in percent of the reference or control that the assay uses: 100%
The estimate for compound 4 lay 2 percentage points below the measured number, and the stated range covers the measured number.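

In this assay, chloro in place of hydrogen on an aromatic carbon of the core of compound 1 gives a number 4 percentage points lower from compound 1 to compound 4 (within the scatter). Set beside the earlier step on the other core, the change carries over from one core to the other without a measurable difference in maximal response: the same change on two cores in this assay, a number 2 percentage points lower (within the scatter) from compound 2 to compound 3 and a number 4 percentage points lower (within the scatter) from compound 1 to compound 4, 2 percentage points apart, within the scatter of two such steps This shows only that the chloro leaves the maximal response within the scatter on these two cores; it does not show that the same would hold on a third core, and as the chloro stands ortho to a group of 6 heavy atoms in compound 4 but elsewhere in compound 3, core and place are not separated, nor does it speak to anything beyond the maximal response.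

The compounds shown leave open whether the chloro at another place on the ring of compound 1 would behave alike. They also leave open whether a different group on that ring, such as a methoxy group, an amine or a carboxylic acid, would carry from core to core in the same way.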